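The source may hold more compounds than are shown below. What is called first, only, known or untested is meant among the compounds shown, and "the series" means these compounds.

The measured compounds in an assay on cells for agonist activity at vitamin D3 receptor (Homo sapiens), read by microscopy; a lower number here means that less compound is needed, a higher number that more compound is needed for the effect:
Compound 1, `C#CCCOC(=O)c1ccc(C(CC)(CC)c2ccc(C#CC(O)(CC)CC)c(C)c2)n1CC`, gives only a limit of the assay, > 50 nM.
Compound 2, `CCN(CC)CCNC(=O)c1cc(C(CC)(CC)c2ccc(C#CC(O)(CC)CC)c(C)c2)cn1CC`, gives 6.98 nM.
Compound 3, `CCn1cc(C(CC)(CC)c2ccc(C#CC(O)(CC)CC)c(C)c2)cc1C(=O)NCCN(C)C`, gives 19.3 nM.

For the measured compounds named here, of the two compounds with a real number, compound 3 has the higher one; the single step between them, a 2.8-fold higher number from compound 2 to compound 3 (0.44 log units; beyond the scatter), is modest but lies beyond the scatter. For compound 1 only the limit is known, (the limit of > 50 nM in this assay, at which 1 of the 3 values shown sits), so it cannot be placed relative to the others.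

Compound 4, `CCn1cc(C(CC)(CC)c2ccc(C#CC(O)(CC)CC)c(C)c2)cc1C(=O)NCC(=O)O`, differs from compound 3 in one place: carboxy in place of (dimethylamino)methyl on a saturated chain carbon bound to an amide-type nitrogen. Going by the values given here, the only measured step that touches this end of the molecule is a 2.8-fold higher number from compound 2 to compound 3 (0.44 log units; beyond the scatter), where merely trimming the two ethyl groups of the amine to methyls already pushed the number up. Among the compounds with values here, the change to compound 4 goes much further, removing the (dimethylamino)methyl group entirely and putting a carboxy group in its place, and no measured step shows what a carboxy group does here. The expectation is therefore a step in the same direction, likely larger, with real uncertainty and a fair chance that the assay reports only a limit. The estimate for compound 4 is 45 nM, in a range from 10 nM to 200 nM, meaning an expected step of a 2.3-fold higher number from compound 3 to compound 4 (0.37 log units; beyond the scatter).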

Compound 4, half-maximal effective concentration: 54.3 nM
For compound 4 the middle estimate is 1.2-fold (0.08 log units) below the measured one; the measured number falls inside the stated range.
By their numbers in this assay, from the lowest: compound 2; then compound 3; then compound 4.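

In this assay, the end of the amide side chain still gives a real number without any amine: putting carboxy in place of (dimethylamino)methyl produces a 2.8-fold higher number from compound 3 to compound 4 (0.45 log units; beyond the scatter) and so takes the series beyond the earlier trimming of ethyl groups to methyl groups. Set against the diethylamino compound, the difference on the same saturated chain carbon widens to a 7.8-fold higher number from compound 2 to compound 4 (0.89 log units; beyond the scatter), the largest step among the compounds with real numbers, so the order runs from diethylamino through dimethylamino to carboxy at this end of the molecule. Nothing shown here explains these steps, which record only how the number moves with each change.

As far as these compounds go, one change both removed the amine and introduced the carboxylic acid, so it remains open which of the two drives the higher number. A hydroxyl or a primary amide on that saturated chain carbon would separate the two, while a longer chain carrying the carboxylic acid or a cyclic amine such as piperidine would show how far this end of the molecule can vary.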